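Halogen and hydroxy changes on a shared core

The source may hold more compounds than are shown below. What is called first, only, known or untested is meant among the compounds shown, and "the series" means these compounds.

Measured so far:
compound 1 `CC(C)(C)C1=NN(c2ccc(Cl)cc2)C(c2ccc(F)cc2)C1`: 0%
compound 2 `CC(C)(C)C1=NN(c2ccc(Cl)cc2)C(c2ccc(Cl)cc2)C1`: 11.8%
compound 3 `CC(C)(C)C1=NN(c2ccc(Cl)cc2)C(c2ccc(O)c(F)c2)C1`: 98.5%

In an assay on isolated protein for inhibition of protein kinase C zeta type (Homo sapiens), with a stated time of 4 min, tested at 62.5 uM (a higher number here means more inhibition at the concentration tested (going by the name of the read-out), a lower number less inhibition), compound 1 gives 0%, compound 2 gives 11.8% and compound 3 gives 98.5%. The change chloro in place of fluoro on an aromatic carbon made the step of a number 11.8 percentage points higher from compound 1 to compound 2 (beyond the scatter). The change of core, (3-fluoro-4-hydroxyphenyl in place of 4-fluorophenyl on a saturated ring carbon), made the step of a number 98.5 percentage points higher from compound 1 to compound 3 (beyond the scatter), and a number 86.7 percentage points higher from compound 2 to compound 3 (beyond the scatter).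

Compound 4 `CC(C)(C)C1=NN(c2ccc(Cl)cc2)C(c2ccc(O)c(Cl)c2)C1` is not yet measured. It differs from compound 3 by chloro in place of fluoro on an aromatic carbon, the same kind of change as from compound 1 to compound 2, but at another place: there the chloro sat para to a large group, here it sits ortho to a hydroxy group and meta to a large group. Because compound 3 already gives 98.5% and the earlier step was a number 11.8 percentage points higher from compound 1 to compound 2 (beyond the scatter), the step expected for compound 4 is a number 3.5 percentage points lower from compound 3 to compound 4 (within the scatter), small and near the top of the scale. Compound 4 is estimated at 95%, between 78% and 100%.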

Compound 4, a percentage reported as inhibition, at one concentration (the size of the read-out at that concentration, not a potency): 94.5%
Compound 4: middle estimate off by 0.5 percentage points, on the high side; the range from low to high includes it.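

In this assay, chloro in place of fluoro does not carry over with one size from one core to the other: the same change on two cores in this assay, a number 11.8 percentage points higher (beyond the scatter) from compound 1 to compound 2 and a number 4 percentage points lower (within the scatter) from compound 3 to compound 4, 15.8 percentage points apart, beyond the scatter of two such steps With the hydroxy group present the step reads a number 4 percentage points lower from compound 3 to compound 4 (within the scatter), while the 3-chloro-4-hydroxyphenyl group leaves the compounds without hydroxy far behind, a number 82.7 percentage points higher from compound 2 to compound 4 (beyond the scatter) and a number 94.5 percentage points higher from compound 1 to compound 4 (beyond the scatter). Both hydroxy compounds read near the top of the scale at a single concentration, so this does not show whether the halogen swap would matter in potency, and two pairs set no rule for the series.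

Open, as far as these compounds go, is whether the hydroxy group alone, without a halogen on that ring, gives the same read-out. Also open, from the compounds shown here alone, is whether a methoxy group, an amine or a carboxylic acid in its place would keep it.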